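Aryl Variation on the Shared Core: Outlook for Compound 4

A few compounds are considered here, and "the series" means these few. Any claim that something is new, unique, unknown or untested is made for them only; others in the source may bear on it.

Compound 3 `COc1cc(/C=C/C(=O)C(=Cc2cn(-c3ccccc3)nc2-c2ccccc2O)C(=O)/C=C/c2ccc(O)c(OC)c2)ccc1O` carries a 2-hydroxyphenyl group on the shared core and gives 97% in a functional assay on MCF7 cells (Homo sapiens) for antiproliferative activity, read by MTT assay, with a stated time of 24 h, tested at 0.001 ug/mL (on this read-out higher numbers stand for a weaker effect at the one concentration tested and lower numbers for a stronger effect), level at the digits shown with compound 1 `O=Cc1cn(-c2ccccc2)nc1-c1ccccc1O` at 97%, the two together being the lowest of the three numbers, while compound 2 `COc1cc(/C=C/C(=O)C(=Cc2cn(-c3ccccc3)nc2-c2ccc([N+](=O)[O-])cc2)C(=O)/C=C/c2ccc(O)c(OC)c2)ccc1O` gives 98%, within the scatter of both. Within the data shown here, the one measured step that bears on the present change is a number 1 percentage points lower from compound 2 to compound 3 (within the scatter). Compound 4 `COc1cc(/C=C/C(=O)C(=Cc2cn(-c3ccccc3)nc2-c2cccc([N+](=O)[O-])c2)C(=O)/C=C/c2ccc(O)c(OC)c2)ccc1O` differs from compound 3 by 3-nitrophenyl in place of 2-hydroxyphenyl on an aromatic carbon. Because the exchange a number 1 percentage points lower from compound 2 to compound 3 (within the scatter) stayed within the scatter, no step beyond the scatter is expected from this further aryl exchange, and the estimated step is no change at the digits printed from compound 3 to compound 4 (within the scatter). For compound 4 the expected value is 97%, with a range from 90% to 102%.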

Compound 4, a percentage reported as activity, at one concentration (the size of the read-out at that concentration, not a potency): 96%
Compound 4: middle estimate off by 1 percentage points, on the high side; low and high end bracket the measured number.
By their numbers in this assay, from the lowest: compounds 4, 1, 3 and 2 (each within the scatter of the next).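

In this assay 3-nitrophenyl in place of 2-hydroxyphenyl gives a number 1 percentage points lower from compound 3 to compound 4 (within the scatter) and 3-nitrophenyl in place of 4-nitrophenyl gives a number 2 percentage points lower from compound 2 to compound 4 (within the scatter). On this aromatic carbon, the two nitrophenyl groups now stand within the scatter of each other, so the new compound adds an isomer pair to the aryl exchange without separating the series. No measurement at hand accounts for this outcome. Open, on these data alone, is whether an amine or a carboxylic acid on this phenyl ring would shift the number. Also open, as far as these compounds go, is whether a longer chain in place of the aryl group would do so.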